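Swapping bromo for methylsulfanyl on a weak antiproliferative amide

The compounds below may be only part of what the source reports. "The series", "measured", "known", "first", "only" and "open" are said of these compounds alone.

Measured so far:
- compound 1 `NC(=O)c1c(NC(=O)c2ccccc2F)sc2c1CCN(Cc1ccc(Cl)cc1Cl)C2` — 27500 nM
- compound 2 `NC(=O)c1c(NC(=O)c2ccccc2Cl)sc2c1CCN(C(=S)Nc1cccnc1)C2` — > 50000 nM
- compound 3 `NC(=O)c1c(NC(=O)c2ccccc2Br)sc2c1CCN(C(=S)Nc1ccccc1Cl)C2` — 46900 nM

Of the compounds shown here, three share a core and have been tested in a functional assay on HeLa cells (Homo sapiens) for antiproliferative activity, with a stated time of 24 h; a higher number here means a weaker inhibitor, a lower number a stronger inhibitor. Compound 1 `NC(=O)c1c(NC(=O)c2ccccc2F)sc2c1CCN(Cc1ccc(Cl)cc1Cl)C2` gives 27500 nM in this assay. Compound 2 `NC(=O)c1c(NC(=O)c2ccccc2Cl)sc2c1CCN(C(=S)Nc1cccnc1)C2` reaches only the limit of this assay, > 50000 nM, so no number is known for it; that limit is recorded as the limit of > 50000 nM in this assay, at which 1 of the 3 values shown sits. Compound 3 `NC(=O)c1c(NC(=O)c2ccccc2Br)sc2c1CCN(C(=S)Nc1ccccc1Cl)C2` gives 46900 nM. The numbers of compound 3 and compound 1 lie within the usual scatter of each other, so neither can be called stronger or weaker; both sit at high concentrations.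

Compound 4 `CSc1ccccc1C(=O)Nc1sc2c(c1C(N)=O)CCN(C(=S)Nc1ccccc1Cl)C2` has not yet been measured. It differs from compound 3 in one place: methylsulfanyl in place of bromo on an aromatic carbon. Among the compounds with values here, no measured pair in this set shows what such a change does, so there is no basis for expecting a step beyond the scatter in either direction. Compound 4 is therefore expected to give roughly 45000 nM, with a plausible range from 15000 nM to 150000 nM, in this assay. The expected step is a 1.0-fold lower number from compound 3 to compound 4 (0.02 log units; within the scatter), essentially no change.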

Compound 4, half-maximal inhibitory concentration: 34700 nM
Compound 4: middle estimate off by 1.3-fold (0.11 log units), on the high side, and the stated range covers the measured number.
By their numbers in this assay, from the lowest: compounds 1, 4 and 3 (each within the scatter of the next). At a limit, above all of these: compound 2.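

Within the data shown here, compounds 3 and 4 form the first pair in this set that differs in only one place, and in this assay the pair shows a 1.4-fold lower number from compound 3 to compound 4 (0.13 log units; within the scatter). On an aromatic carbon ortho to a large group, methylsulfanyl can therefore take the place of bromo without separating the two compounds, even though it brings one more heavy atom and one hydrogen-bond acceptor. Nothing measured here bears on why the two compounds read alike.

As far as these compounds go, whether any group at this position can move the number beyond the scatter stays open, and an amine, a carboxylic acid or a longer chain such as ethylsulfanyl would test that. From the compounds shown here alone, the pair also covers only the rest of compound 3, so the same change on compound 1 remains unknown.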